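This account rests on a few compounds, and the source may have more. Where it says the series, first, only, none or still open, it means among the compounds named here.

In an ADME assay for permeability, using PAMPA, with a stated time of 4 h, at pH 7.4 (on this read-out lower numbers stand for lower permeability and higher numbers for higher permeability), compound 1 (`NC/C=C\CN(C[C@H]1Cc2ncccc2CN1)[C@H]1CCCc2cccnc21`) gives 68 nm/s, compound 2 (`NC(=O)NC/C=C/CN(C[C@H]1Cc2ncccc2CN1)[C@H]1CCCc2cccnc21`) gives 2 nm/s, and compound 3 (`CN(CCCCN(C[C@H]1Cc2ncccc2CN1)[C@H]1CCCc2cccnc21)C1CCC(F)(F)CC1`) gives 310 nm/s, the highest of the three. Compound 4 (`CN(CCCCN(C[C@H]1Cc2ncccc2CN1)[C@H]1CCCc2cccnc21)C1CCOCC1`) differs from compound 3 in one place: oxan-4-yl in place of 4,4-difluorocyclohexyl on an amine nitrogen, with oxan-4-yl in place of 4,4-difluorocyclohexyl on an amine nitrogen. Within the data shown here, no measured step makes this exact swap. Among the measured compounds shown here, the only guide is a 34-fold lower number from compound 1 to compound 2 (1.53 log units; beyond the scatter), a large step at a different place, on a saturated chain carbon bound to an amine nitrogen. There too the entering group holds oxygen and the number fell, so a fall is the likelier direction here. In this assay the expected step is a 2.8-fold lower number from compound 3 to compound 4 (0.45 log units; beyond the scatter), a moderate fall, smaller than that large one. For compound 4 the estimated value is 110 nm/s, with an expected range of 35 nm/s to 280 nm/s.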

Compound 4, apparent permeability: 490 nm/s
Estimate against measurement, compound 4: 4.5-fold (0.65 log units) below; measured number outside the range, above it.
By their numbers in this assay, from the lowest: compound 2; then compound 1; then compounds 3 and 4 (each within the scatter of the next).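

In this assay, oxan-4-yl in place of 4,4-difluorocyclohexyl on this amine nitrogen gives a step (a 1.6-fold higher number from compound 3 to compound 4 (0.20 log units; within the scatter)) that stays inside the usual scatter, so here the entering oxygen brings no clear change, and the two rings cannot be told apart on this read-out. The group of 11 heavy atoms carrying oxan-4-yl also stands well clear of the group of 7 heavy atoms (a 250-fold higher number from compound 2 to compound 4 (2.39 log units; beyond the scatter)) and the group of 4 heavy atoms (a 7.2-fold higher number from compound 1 to compound 4 (0.86 log units; beyond the scatter)). On these data alone, what a piperidine ring or a plain cyclohexyl would give on this amine nitrogen stays open. Nothing at hand explains any of these steps.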